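Replacing the Acid Tail of Compound 1 with a Hydroxyethyl Piperidine

The source may report more compounds than this note shows. Statements on the series, on what has been measured and on what is new or still open speak of the compounds shown alone.

Two analogues sharing one spiro core have been measured in an assay on HEK293 cells for displacement of a labelled ligand from NPC1-like intracellular cholesterol transporter 1 (Homo sapiens); a lower number here means a stronger inhibitor, a higher number a weaker inhibitor. Compound 1 `CC(C)(C)c1ccc(C(=O)N2CCC3(CC2)C(=O)N(CC(=O)NCCC(=O)O)CN3c2ccccc2)cc1` gives 11400 nM, the highest of the two numbers. Compound 2 `NC(=O)C1CCCN(C(=O)CN2CN(c3ccccc3)C3(CCN(C(=O)c4ccc(C5CCCCC5)cc4)CC3)C2=O)C1` gives 3100 nM in this assay, a lower number that lies beyond the usual scatter; the two differ in more than one place, so the gap is not attributed to any single change.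

Compound 3 `CC(C)(C)c1ccc(C(=O)N2CCC3(CC2)C(=O)N(CC(=O)N2CCCCC2CCO)CN3c2ccccc2)cc1` is compound 1 with a single alteration: 2-(2-hydroxyethyl)piperidin-1-yl in place of (2-carboxyethyl)amino on a carbonyl carbon. The acid is lost, a ring is gained, and a hydrogen-bond donor is removed in the process.

Among the measured compounds shown here, compound 1 is the weaker of the two measured compounds in this assay, and a change of this kind is expected to move the number downward by a moderate step, a 3.3-fold lower number from compound 1 to compound 3 (0.51 log units; beyond the scatter), though with real uncertainty because no directly comparable pair is available. The estimate for compound 3 is therefore 3500 nM, with a plausible range from 900 nM to 13000 nM.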

Compound 3, half-maximal inhibitory concentration: 6100 nM
Compound 3: the middle estimate sits 1.7-fold (0.24 log units) below what was measured, and the stated range covers the measured number.
By their numbers in this assay, from the lowest: compounds 2, 3 and 1 (each within the scatter of the next, the first and the last beyond it).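

In this assay, setting 2-(2-hydroxyethyl)piperidin-1-yl in place of (2-carboxyethyl)amino on this carbonyl carbon gives a 1.9-fold lower number from compound 1 to compound 3 (0.27 log units; within the scatter). This position therefore accepts the loss of the carboxylic acid and the gain of a six-membered non-aromatic ring, and the larger group gives no step that stands clear of repeat measurements, so the acid is not shown to be needed for the number in this assay. Nothing available bears on why the step is this size.

The compounds shown leave open whether the ring and the hydroxyethyl arm contribute separately, since the two enter together. A plain piperidin-1-yl or an open (2-hydroxyethyl)amino group on the same carbonyl carbon would separate them, and a primary amine at the end of the chain would test another kind of tail.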